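Working notes: from compound 3 to compound 4

The source may report more compounds than this note shows. Statements on the series, on what has been measured and on what is new or still open speak of the compounds shown alone.

Measured so far in a functional assay on ECa-109 cells (Homo sapiens) for antiproliferative activity, read by MTT assay, with a stated time of 72 h; on this read-out lower numbers stand for stronger inhibition and higher numbers for weaker inhibition:
compound 1, `CCCSc1nc(N/N=C(\C)c2ccc(OC)cc2)c2nnn(Cc3ccccc3)c2n1`, gives > 64000 nM, a limit of the assay.
compound 2, `CCCSc1nc(N/N=C(\C)c2ccccc2O)c2nnn(Cc3cccc(Cl)c3)c2n1`, gives 13000 nM.
compound 3, `CCCSc1nc(N/N=C/c2cccs2)c2nnn(Cc3ccccc3)c2n1`, gives > 64000 nM, again a limit.

Among the compounds with values here, compound 3 thus stands at the limit of this assay, with no number of its own; compound 1 sits at the same place, (the limit of > 64000 nM in this assay, at which 2 of the 3 values shown sit), and compound 2 is the only measured compound that returns a number. Compound 4, `CCCSc1nc(N/N=C/c2cccc(Cl)c2)c2nnn(Cc3ccccc3)c2n1`, differs from compound 3 in one place: 3-chlorophenyl in place of thiophen-2-yl on a carbon with a double bond to nitrogen. Within the data shown here, no measured step covers this change. The step from compound 3 to compound 4 is expected to be an at least 1.0-fold lower number from compound 3 to compound 4 (0.02 log units; that floor lies within the scatter), nothing beyond the scatter, with a real chance that this assay again reports only a limit. Compound 4 is estimated at 60000 nM, with a range from 15000 nM to 200000 nM.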

Compound 4, half-maximal inhibitory concentration: > 64000 nM
Compound 4: no number, only a limit; the forecaster's own chance of this, stated with the estimate: 60%; middle value at least 1.0-fold (0.02 log units) from the limit.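

No step can be read between compound 3 and compound 4 in this assay, since each returns only a limit: the limit of > 64000 nM in this assay, at which 3 of the 4 values shown sit.

As far as these compounds go, whether 3-chlorophenyl in place of thiophen-2-yl shifts the inhibition at all remains open.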